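The source may report more compounds than this note shows. Statements on the series, on what has been measured and on what is new or still open speak of the compounds shown alone.

Compound 1 `Nc1ccccc1NC(=O)c1ccc(CSC(=S)N2CCc3cc([N+](=O)[O-])ccc32)cc1` and compound 2 `Nc1ccccc1NC(=O)c1ccc(CSC(=S)N2CCN(Cc3ccncc3)CC2)cc1` share a core and differ in one group attached to it. In a functional assay on MGC-803 cells (Homo sapiens) for antiproliferative activity, read by CCK-8 assay, with a stated time of 72 h, tested at 2 uM (on this read-out lower numbers stand for a weaker effect and higher numbers for a stronger effect at the one concentration tested), compound 1 gives 26.8%, and in this assay compound 2 gives 18.4%, a number that lies within the usual scatter of the number for compound 1. Compound 3 `CN1CCN(C(=S)SCc2ccc(C(=O)Nc3ccccc3N)cc2)CC1` carries a single change from compound 2: hydrogen in place of pyridin-4-yl on a saturated chain carbon bound to an amine nitrogen in a ring. Among the measured compounds shown here, no measured pair shows a step of this kind, so in this assay the step is expected to be none beyond the scatter, with a number 2.4 percentage points lower from compound 2 to compound 3 (within the scatter) estimated as small. Compound 3 is expected to give about 16%, between 4% and 30%.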

Compound 3, a percentage reported as inhibition, at one concentration (the size of the read-out at that concentration, not a potency): 29.6%
Compound 3: middle estimate off by 13.6 percentage points, on the low side, and the stated range covers the measured number.
By their numbers in this assay, from the lowest: compounds 2, 1 and 3 (each within the scatter of the next, the first and the last beyond it).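

In this assay, among the compounds shown here, the change to hydrogen in place of pyridin-4-yl gives a number 11.2 percentage points higher from compound 2 to compound 3 (beyond the scatter) and is the first step read at this position. Cut one bond further out, the change is (pyridin-4-yl)methyl to methyl, so here the read-out does not depend on keeping the pyridine ring, and the smaller group gives the larger number. Nothing at hand explains this step. From the compounds shown here alone, whether an ethyl group, a benzyl group or a longer chain at this position would match compound 3 or compound 2 stays open.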